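A few compounds are considered here, and "the series" means these few. Any claim that something is new, unique, unknown or untested is made for them only; others in the source may bear on it.

In a functional assay on MDA-MB-231 cells (Homo sapiens) for antiproliferative activity, read by MTT assay, with a stated time of 72 h (a higher number here means a weaker inhibitor, a lower number a stronger inhibitor), compound 1 `O=C(Nc1ccc(-c2noc(-c3cccc(NS(=O)(=O)c4ccccc4)c3)n2)c(Cl)c1)c1cccnc1` reaches only the limit of > 10000 nM, not a number. Compound 2 `O=C(Nc1ccc(-c2noc(-c3cccc(NS(=O)(=O)c4ccc(C(F)(F)F)cc4)c3)n2)c(Cl)c1)c1cccnc1` likewise sits at the limit of > 10000 nM. The change between them, (trifluoromethyl in place of hydrogen on an aromatic carbon), therefore gives a step that the two limits leave unreadable from compound 1 to compound 2, since (the limit of > 10000 nM in this assay, at which 2 of the 3 values shown sit). Among the compounds with values here, compound 3 `O=C(Nc1cccc(-c2nc(-c3ccc(NC(=O)c4cccnc4)cc3Cl)no2)c1)Nc1cccc(C(F)(F)F)c1` stands apart: in this assay compound 3 gives 1900 nM, the only number among the three. How the core of compound 3 differs from the core of compound 1 is not broken down here. Compound 4 `O=C(Nc1cccc(-c2nc(-c3ccc(NC(=O)c4cccnc4)cc3Cl)no2)c1)Nc1cc(C(F)(F)F)cc(C(F)(F)F)c1` has not yet been measured; it carries the same kind of change as compound 2, (trifluoromethyl in place of hydrogen on an aromatic carbon), though here the place is meta to a large group and meta to a trifluoromethyl group rather than para to a large group. Within the data shown here, with the earlier step unreadable, the expectation for compound 4 is only that it stays near compound 3, an estimated step of a 1.3-fold lower number from compound 3 to compound 4 (0.10 log units; within the scatter). Compound 4 is thus expected to give about 1500 nM, between 450 nM and 6000 nM.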

Compound 4, half-maximal inhibitory concentration: 1900 nM
Estimate against measurement, compound 4: 1.3-fold (0.10 log units) below; the range from low to high includes it.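

In this assay, adding a second trifluoromethyl to the core of compound 3 gives no change at the digits printed from compound 3 to compound 4 (within the scatter). Within the data shown here, on the core of compound 1 the same change cannot be read, so the two cores offer no size to compare: the limit of > 10000 nM in this assay, at which 2 of the 4 values shown sit. The new step therefore shows only that this one change leaves the value unmoved on the core of compound 3, at a place meta to a large group and meta to a trifluoromethyl group; it does not show that the change acts alike on both cores.

The compounds shown leave open whether an amine or a carboxylic acid at that place would move the value. They also leave open whether any group on the core of compound 1 would give a number rather than a limit.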